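Compound 3 to compound 4: a sulfonyl replacement at the limit

A few compounds are considered here, and "the series" means these few. Any claim that something is new, unique, unknown or untested is made for them only; others in the source may bear on it.

In a functional assay on HeLa cells (Homo sapiens) for antiproliferative activity, read by MTT assay, with a stated time of 48 h (a higher number here means a weaker inhibitor, a lower number a stronger inhibitor), compound 1 `Cn1cc(-c2cnc3ccnc(NC(=O)c4ccc(F)cc4)c3c2)cn1` gives > 50000 nM, a limit of the assay and not a number. Compound 2 `COc1ccc(C(=O)Nc2nccc3ncc(-c4cnn(C)c4)cc23)cc1` gives > 50000 nM, which is also a limit. Compound 3 `Cn1cc(-c2cnc3ccnc(NC(=O)c4cccnc4)c3c2)cn1` gives > 50000 nM, likewise a limit. The whole record so far is the limit of > 50000 nM in this assay, at which 3 of the 3 values shown sit.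

Compound 4 `Cn1cc(-c2cnc3ccnc(NS(=O)(=O)c4cccs4)c3c2)cn1` carries (thiophen-2-yl)sulfonyl in place of (pyridin-3-yl)carbonyl on a nitrogen on an aromatic ring.

The measured steps bear on this only loosely. They are a step that the two limits leave unreadable from compound 1 to compound 2, a step that the two limits leave unreadable from compound 1 to compound 3 and a step that the two limits leave unreadable from compound 2 to compound 3. None has a readable size, and none replaces the carbonyl.

With no size to carry over, only a small move toward stronger inhibition is expected in this assay, and a further reading at the limit is the likeliest result. The expected change is an at least 1.2-fold lower number from compound 3 to compound 4 (0.09 log units; that floor lies within the scatter). For compound 4 the estimate is 40000 nM, with an expected range from 10000 nM to 60000 nM.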

Compound 4, half-maximal inhibitory concentration: 17400 nM
The estimate for compound 4 lay 2.3-fold (0.36 log units) above the measured number, and the stated range covers the measured number.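

In this assay, the nitrogen on an aromatic ring proves to be a place where a change can bring a reading off the limit: (thiophen-2-yl)sulfonyl in place of (pyridin-3-yl)carbonyl gives an at least 2.8-fold lower number from compound 3 to compound 4 (0.45 log units; beyond the scatter). Going by these compounds alone, this is the first step with a readable size, as the steps among compound 1, compound 2 and compound 3 cannot be read. The size is only a floor, because the reading for compound 3 is a limit: the limit of > 50000 nM in this assay, at which 3 of the 4 values shown sit.

The step replaces the carbonyl and the ring together, and the compounds shown do not separate the two, as neither (pyridin-3-yl)sulfonyl nor (thiophen-2-yl)carbonyl stands among them. From the compounds shown here alone, whether the thiophene ring is needed at all also stays open, since a plain methylsulfonyl group on this nitrogen is not among them either.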